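Removing the trifluoromethyl group from compound 1

This account rests on a few compounds, and the source may have more. Where it says the series, first, only, none or still open, it means among the compounds named here.

Measured so far in a functional assay on HeLa cells (Homo sapiens) for antiproliferative activity, read by MTT assay, with a stated time of 48 h; a higher number here means a weaker inhibitor, a lower number a stronger inhibitor:
- compound 1 `COc1ccc(-c2cn3cc(C4=CCN(C(=O)c5ccccc5C(F)(F)F)CC4)ccc3n2)cc1OC` gives 7950 nM
- compound 2 `COc1ccc(-c2cn3cc(C4=CCN(C(=O)C(C)(C)C)CC4)ccc3n2)cc1OC` gives 5480 nM

Among the measured compounds shown here, with only two measured compounds, compound 1 has one neighbour, and the single measured step, a 1.5-fold lower number from compound 1 to compound 2 (0.16 log units; within the scatter), does not separate the pair. The next compound is compound 3 `COc1ccc(-c2cn3cc(C4=CCN(C(=O)c5ccccc5)CC4)ccc3n2)cc1OC`, which differs from compound 1 as follows: hydrogen in place of trifluoromethyl on an aromatic carbon. In words, hydrogen replaces trifluoromethyl on an aromatic carbon, turning 2-(trifluoromethyl)phenyl into phenyl. For the measured compounds named here, the one measured step bears on this only indirectly: it exchanges the entire 2-(trifluoromethyl)phenyl group for tert-butyl on a carbonyl carbon, and the size of that step stays within the scatter. Going by the values given here, no measured step isolates the trifluoromethyl group itself, so no shift beyond the scatter is expected in either direction in this assay. The expected step is a 1.2-fold lower number from compound 1 to compound 3 (0.09 log units; within the scatter), and this estimate remains tentative. For compound 3 the estimated value is 6500 nM, with an expected range from 3000 nM to 14000 nM as its limits.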

Compound 3, half-maximal inhibitory concentration: 10200 nM
Beside the measured number, compound 3's estimate is 1.6-fold (0.20 log units) below it; the measured number falls inside the stated range.
By their numbers in this assay, from the lowest: compounds 2, 1 and 3 (each within the scatter of the next).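

In this assay, the trifluoromethyl group on the aromatic carbon is now isolated as a single change, and a 1.3-fold higher number from compound 1 to compound 3 (0.11 log units; within the scatter) gives no readable effect of replacing it with hydrogen. The comparison of phenyl and tert-butyl on the carbonyl carbon is also direct now, and a 1.9-fold higher number from compound 2 to compound 3 (0.27 log units; within the scatter) does not separate those groups either. So neither the loss of trifluoromethyl nor the change of the whole group on the carbonyl carbon moves the number beyond the scatter, and no measurement on hand offers an explanation for this.

Still open, on these data alone, is whether an amine or a carboxylic acid on this aromatic carbon would give a step beyond the scatter. Also open, as far as these compounds go, is whether a longer chain on the carbonyl carbon, in place of phenyl or tert-butyl, would separate from these compounds.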